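A few compounds are considered here, and "the series" means these few. Any claim that something is new, unique, unknown or untested is made for them only; others in the source may bear on it.

Measured so far in a functional assay on cells for agonist activity at Free fatty acid receptor 1 (Homo sapiens), read by FLIPR and calcium flux, with a stated time of 100 s; a higher number here means that more compound is needed for the effect, a lower number that less compound is needed:
compound 1, `Cc1ccccc1COc1ccc(N2CCC[C@H]2CC(=O)O)cn1`: 450 nM
compound 2, `O=C(O)C[C@@H]1CCCN1c1ccc(Oc2ccc(Cl)cc2Cl)cc1`: 360 nM

Compound 2 holds the lowest of the two numbers in this assay, but its nearest neighbour is compound 1, and the gap between the two values lies within the scatter of the assay, so no order can be read from them. Within the data shown here, no step between measured compounds that differ in a single place is available in this pair, and the two compounds differ in more than one place.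

Compound 3, `O=C(O)C[C@@H]1CCCN1c1ccc(Oc2ccc(Cl)cc2)cc1`, is not yet measured. It differs from compound 2 by hydrogen in place of chloro on an aromatic carbon; the same difference, cut one bond further out, reads 2,4-dichlorophenyl to 4-chlorophenyl. Among the measured compounds shown here, nothing among the measured compounds shows what this change does in this assay. With one chlorine taken away from the aryl ether, the expectation for compound 3 is a moderate rise in the number in this assay, though a result within the scatter cannot be excluded. For compound 3 the expected step is a 2.2-fold higher number from compound 2 to compound 3 (0.35 log units; beyond the scatter). The value expected for compound 3 in this assay is 800 nM, with a range from 300 nM to 2500 nM.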

Compound 3, half-maximal effective concentration: 290 nM
For compound 3 the middle estimate is 2.8-fold (0.44 log units) above the measured one, and the stated range ends above it.
By their numbers in this assay, from the lowest: compounds 3, 2 and 1 (each within the scatter of the next).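

In this assay, the exchange of 2,4-dichlorophenyl for 4-chlorophenyl, with hydrogen in place of chloro on an aromatic carbon ortho to a large group, gives a 1.2-fold lower number from compound 2 to compound 3 (0.09 log units; within the scatter). Among these compounds, this is the first comparison between compounds that differ in one place, and it shows that, on this aryl ether and within the scatter of this assay, the number does not depend on this chloro group, so compound 2 and compound 3 cannot be told apart. No evidence at hand bears on the reason for this result.

The compounds shown leave open whether a fluoro, methyl or methoxy group on the same aromatic carbon would give a number in line with those of hydrogen and chloro, or one clearly apart from them. Among the compounds shown here, they also leave open what the remaining chloro group contributes, since no pair here sets it against hydrogen, trifluoromethyl or a nitrile, and compound 1 differs from compound 3 in more than one place and so says nothing on this point.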